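The compounds below may be only part of what the source reports. "The series", "measured", "known", "first", "only" and "open" are said of these compounds alone.

In a functional assay on CWR22R cells (Homo sapiens) for inhibition (on this read-out higher numbers stand for weaker inhibition and lower numbers for stronger inhibition), compound 3 `CCn1c(=O)/c(=C2\Sc3ccc(OC)cc3N2C)s/c1=C\c1ccncc1Nc1ccccc1C` gives 410 nM, which places it at the low end of the three numbers measured, alongside compound 1 `CCn1c(=O)/c(=C2\Sc3ccccc3N2C)s/c1=C\c1ccncc1Nc1ccccc1C`, and that compound gives 470 nM in this assay, a gap within the scatter. Compound 2 `c1ccc(Nc2nc(-c3nc4ccccc4s3)cs2)cc1` stands well apart, since in this assay compound 2 gives 6900 nM, beyond the scatter from both others.

Compound 4 `CCn1c(=O)/c(=C2\Sc3ccc(OC)cc3N2C)s/c1=C\c1ccncc1Nc1ccccc1Cl` differs from compound 3 in one place: chloro in place of methyl on an aromatic carbon. For the measured compounds named here, no measured step exchanges methyl for chloro at this position, so the data offer no direct precedent. Going by the values given here, the only single-point step recorded, a 1.1-fold lower number from compound 1 to compound 3 (0.06 log units; within the scatter), concerns a methoxy at a different ring and left the number essentially unchanged; it shows that a small peripheral change need not move this assay, but says nothing specific about the change in hand. The expectation is therefore a step of no size beyond the scatter, in no firm direction.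

For compound 4 the estimated value in this assay is 400 nM, with a range from 150 nM to 1100 nM. The expected step from compound 3 to compound 4 is a 1.0-fold lower number from compound 3 to compound 4 (0.01 log units; within the scatter).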

Compound 4, half-maximal inhibitory concentration: 500 nM
The estimate for compound 4 lay 1.3-fold (0.10 log units) below the measured number, and the stated range covers the measured number.
By their numbers in this assay, from the lowest: compounds 3, 1 and 4 (each within the scatter of the next); then compound 2.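

In this assay, chloro in place of methyl on the aromatic carbon ortho to a large group gives a 1.2-fold higher number from compound 3 to compound 4 (0.09 log units; within the scatter), so the two groups cannot be told apart on this read-out. For the compounds shown here, this is the first reading at the 2-methylphenyl position, and it shows that this exchange leaves the number within the scatter, as the methoxy change on the other ring, a 1.1-fold lower number from compound 1 to compound 3 (0.06 log units; within the scatter), did at its own place. Nothing at hand offers an explanation for this result.

On these data alone, what an amine, a carboxylic acid or a longer chain such as propyl would do at this same carbon stays open, so the limits of what this position accepts are unknown. Also open, as far as these compounds go, is whether the exchange of methyl for chloro would read the same on compound 1, which lacks the methoxy.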